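Stereochemically undefined ester analogue in the ileum antagonist series

A few compounds are considered here, and "the series" means these few. Any claim that something is new, unique, unknown or untested is made for them only; others in the source may bear on it.

Measured so far:
compound 1 `CC1=C(C(=O)OCCO[N+](=O)[O-])C(c2cccc3nonc23)C([N+](=O)[O-])=C(C)C1` gives 3890 nM
compound 2 `CC1=C(C(=O)O[C@@H](C)CO[N+](=O)[O-])[C@H](c2cccc3nonc23)C([N+](=O)[O-])=C(C)C1` gives 9430 nM

Both numbers come from a functional assay (ileum) for antagonist activity, with Cavia porcellus as the target; a lower number here means a stronger inhibitor, a higher number a weaker inhibitor. Compound 2 has the highest number of the two; its nearest neighbour is compound 1, with the lower number, and the gap between them lies beyond the scatter. Going by the values given here, no single-change step between the two measured compounds can be drawn, so only the two values themselves are on record.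

Compound 3 `CC1=C(C(=O)OC(C)CO[N+](=O)[O-])C(c2cccc3nonc23)C([N+](=O)[O-])=C(C)C1` is not yet measured. Its relation to compound 2 is: the two compounds have the same atoms and bonds; at least one stereo element is drawn with a configuration in one of them and without one in the other: 2 of 2 stereo elements differ; a stereocentre at a saturated chain carbon is drawn S in compound 2 and without a configuration in compound 3; a stereocentre at a saturated ring carbon is drawn S in compound 2 and without a configuration in compound 3. No change of atoms or bonds is involved, only the loss of drawn configuration at both stereocentres.

Among the compounds with values here, with no comparable step measured, the expected size of the step in this assay is a modest one, if any: the mixture described by compound 3 may contain the material of compound 2 together with its other stereoforms, which could carry it either way. Compound 3 is expected to land at 6500 nM, within 2000 nM to 20000 nM, an expected step of a 1.5-fold lower number from compound 2 to compound 3 (0.16 log units; within the scatter) that need not exceed the scatter.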

Compound 3, half-maximal inhibitory concentration: 6380 nM
Compound 3: middle estimate off by 1.0-fold (0.01 log units), on the high side; measured number inside the range.
By their numbers in this assay, from the lowest: compounds 1, 3 and 2 (each within the scatter of the next, the first and the last beyond it).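

In this assay, methyl in place of hydrogen on a saturated chain carbon bound to an oxygen next to a carbonyl group and a saturated chain carbon now has a readable step, a 1.6-fold higher number from compound 1 to compound 3 (0.21 log units; within the scatter), and that step stays within the scatter, so this change does not separate the two compounds in this read-out. Removing the drawn configuration at both stereocentres gives a 1.5-fold lower number from compound 2 to compound 3 (0.17 log units; within the scatter), also within the scatter, so the material drawn S at both stereocentres and the material drawn without configuration cannot be told apart here. The reading of compound 3 cannot be assigned to any single stereoform because of one feature of the pair: the fact that one of compounds 2 and 3 is drawn with a defined configuration and the other without, at the place where they differ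

Still open, on these data alone, is how each single stereoform other than compound 2 reads, and how much each of the two stereocentres contributes on its own. Also open is how an ethyl group on that saturated chain carbon, or an amine on the ester chain, would read in this assay, since the compounds shown carry only hydrogen or methyl at this place.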